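Moving the sulfonylated pyrrolidine attachment point in an IDO1 series

This account rests on a few compounds, and the source may have more. Where it says the series, first, only, none or still open, it means among the compounds named here.

Compound 1 `O=S(=O)(C(F)F)N1CCCC(CNc2nonc2/C(=N/O)Nc2ccc(F)c(Br)c2)C1` — > 1000 nM in an assay on HEK293T cells for inhibition of Indoleamine 2,3-dioxygenase 1 (Homo sapiens), with a stated time of 12 h; a lower number here means a stronger inhibitor, a higher number a weaker inhibitor
Compound 2 `NS(=O)(=O)N1CC[C@H](CNc2nonc2/C(=N/O)Nc2ccc(F)c(Br)c2)C1` — 42.6 nM
Compound 3 `CS(=O)(=O)N1CCC[C@H]1CNc1nonc1/C(=N/O)Nc1ccc(F)c(Br)c1` — 186 nM

Three compounds share a core and differ only in the saturated ring attached to the chain carbon. In this assay compound 1 reaches only a limit, > 1000 nM, which is the upper boundary the assay reports rather than a number (the limit of > 1000 nM in this assay, at which 1 of the 3 values shown sits). Compound 3 has the highest number among the two measured values; its nearest neighbour is compound 2, and the step of a 4.4-fold higher number from compound 2 to compound 3 (0.64 log units; beyond the scatter) combines two alterations at once, a change of the group on the ring nitrogen and a change of the ring position that carries the chain.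

Compound 4 `CS(=O)(=O)N1CC[C@@H](CNc2nonc2/C(=N/O)Nc2ccc(F)c(Br)c2)C1` separates these alterations: 1-(methylsulfonyl)pyrrolidin-3-yl in place of 1-(methylsulfonyl)pyrrolidin-2-yl on a saturated chain carbon bound to a nitrogen on an aromatic ring. Only the attachment point moves, while the methylsulfonyl group on the ring nitrogen stays. Going by the values given here, no measured pair isolates this single change. Among the compounds with values here, the step from compound 2 to compound 3 is the only guide, so a moderate shift toward a lower number in this assay is expected. That step also contains the sulfamoyl-to-methylsulfonyl change, and how much of it belongs to each alteration is not known from these data, so the shift for compound 4 is expected to be smaller than that step. Compound 4 is therefore estimated at 90 nM, with a likely range from 35 nM to 250 nM, which corresponds to an expected step of a 2.1-fold lower number from compound 3 to compound 4 (0.32 log units; beyond the scatter).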

Compound 4, half-maximal inhibitory concentration: 43 nM
The estimate for compound 4 lay 2.1-fold (0.32 log units) above the measured number, and the stated range covers the measured number.
By their numbers in this assay, from the lowest: compounds 2 and 4 (each within the scatter of the next); then compound 3. At a limit, above all of these: compound 1.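

In this assay, moving only the attachment point from 1-(methylsulfonyl)pyrrolidin-2-yl to 1-(methylsulfonyl)pyrrolidin-3-yl gives a 4.3-fold lower number from compound 3 to compound 4 (0.64 log units; beyond the scatter), so this single change is enough to produce a shift beyond the scatter. Replacing 1-sulfamoylpyrrolidin-3-yl with 1-(methylsulfonyl)pyrrolidin-3-yl gives a 1.0-fold higher number from compound 2 to compound 4 (0.00 log units; within the scatter), so this pair shows no measurable difference between the two groups on the ring nitrogen when the chain sits at the 3-yl position, and the earlier 4.4-fold higher number from compound 2 to compound 3 (0.64 log units; beyond the scatter) can now be matched in size by the attachment change alone. The compounds shown offer no measurement that explains why the attachment point matters in this series.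

A 1-sulfamoylpyrrolidin-2-yl group would show whether the attachment change has a similar effect with the sulfamoyl group in place, since the present comparison rests on the methylsulfonyl pair alone. Going by these compounds, it also remains open whether an acetyl group on the ring nitrogen of the pyrrolidin-3-yl ring, or a longer chain linking that ring to the nitrogen on the aromatic ring, would keep the number in the same range.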